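A few compounds are considered here, and "the series" means these few. Any claim that something is new, unique, unknown or untested is made for them only; others in the source may bear on it.

Three members of one hydrazone series have been measured in a functional assay on PC-3 cells (Homo sapiens) for inhibition; on this read-out lower numbers stand for stronger inhibition and higher numbers for weaker inhibition. Compound 1 `Cc1c(C(=O)N/N=C\c2ccccc2C(F)(F)F)oc2cccc(O)c12` gives 26200 nM in this assay, and compound 2 `Cc1c(C(=O)N/N=C\c2cccc(O)c2O)oc2cccc(O)c12` gives 12200 nM. For compound 3 `Cc1c(C(=O)N/N=C\c2cccnc2)oc2cccc(O)c12` this assay reports only a limit, >= 40000 nM, so no number is known for it. Among the compounds with values here, the one single-point step among the measured compounds is an at least 3.2-fold higher number from compound 2 to compound 3 (0.51 log units; beyond the scatter), and because the step ends at the limit of >= 40000 nM in this assay, at which 1 of the 3 values shown sits, its true size is not known. Compound 4 `Cc1c(C(=O)N/N=C\c2ccccc2)oc2cccc(O)c12` differs from compound 3 by phenyl in place of pyridin-3-yl on a carbon with a double bond to nitrogen. Within the data shown here, no measured step involves a phenyl group, so the change cannot be sized from the data; both compound 1 and compound 2 carry substituted phenyl groups and sit at weak inhibition, and compound 3 sits at a limit. Compound 4 is therefore expected to remain a weak inhibitor, with the step of an at least 1.3-fold lower number from compound 3 to compound 4 (0.12 log units; that floor lies within the scatter) reflecting only an estimate against a limit. The estimated value for compound 4 is 30000 nM, within a range from 10000 nM to 80000 nM.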

Compound 4, half-maximal inhibitory concentration: 29200 nM
Estimate against measurement, compound 4: 1.0-fold (0.01 log units) above; the range from low to high includes it.
By their numbers in this assay, from the lowest: compound 2; then compounds 1 and 4 (each within the scatter of the next). At a limit, above all of these: compound 3.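

In this assay the plain phenyl group gives this position its first unsubstituted reference, and the step is a 1.1-fold higher number from compound 1 to compound 4 (0.05 log units; within the scatter), so hydrogen and trifluoromethyl on the aromatic carbon cannot be told apart here. Against the same reference the step is a 2.4-fold higher number from compound 2 to compound 4 (0.38 log units; beyond the scatter), which makes 2,3-dihydroxyphenyl the only group in this set with a measured step to phenyl beyond the scatter, though a modest one. The remaining step is an at least 1.3-fold lower number from compound 3 to compound 4 (0.13 log units; that floor lies within the scatter); it cannot be read, and whether pyridin-3-yl differs from phenyl stays unsettled, because that step starts from a limit: the limit of >= 40000 nM in this assay, at which 1 of the 4 values shown sits.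

The compounds shown leave open whether one hydroxyl alone would carry the step seen with 2,3-dihydroxyphenyl. They also leave open what an amine or a carboxylic acid on the phenyl group would do to the inhibition.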